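The source may hold more compounds than are shown below. What is called first, only, known or untested is meant among the compounds shown, and "the series" means these compounds.

Measured compounds, each with its value in a functional assay on HepG2 cells (Homo sapiens) for cytotoxicity, read by MTT assay; on this read-out higher numbers stand for weaker inhibition and lower numbers for stronger inhibition:

Compound 1, `CCOc1ccc(NC2=CC(=O)c3ncsc3C2=O)cc1`, gives 23.6 ug/mL. Compound 3, `O=C1C=C(Nc2ccc(F)cc2)C(=O)c2scnc21`, gives 17.9 ug/mL. Compound 2, `O=C1C=C(Nc2cccc(F)c2)C(=O)c2scnc21`, reaches only the limit of this assay, > 100 ug/mL, which is not a number (the limit of > 100 ug/mL in this assay, at which 1 of the 3 values shown sits).

Going by the values given here, compound 3 is thus one of only two compounds with a number, and the other, compound 1, sits within the scatter of it: the step of a 1.3-fold lower number from compound 1 to compound 3 (0.12 log units; within the scatter) is too small to count as a change. All three share the same core, and they differ only in the group on the outer aromatic ring.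

Compound 4, `O=C1C=C(Nc2ccccc2)C(=O)c2scnc21`, carries no group there at all. The change from compound 3 to compound 4 is hydrogen in place of fluoro on an aromatic carbon. Among the compounds with values here, the only measured step that bears on this place is the one from compound 1 to compound 3, where a fluoro replaced an ethoxy and the number moved by a 1.3-fold lower number from compound 1 to compound 3 (0.12 log units; within the scatter), within the scatter. Removing the fluoro in turn is therefore expected to move the number little, if at all, in this assay .

On that basis compound 4 is expected to give about 20 ug/mL, somewhere between 8 ug/mL and 50 ug/mL, an expected step of a 1.1-fold higher number from compound 3 to compound 4 (0.05 log units; within the scatter) from compound 3 to compound 4 .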

Compound 4, half-maximal inhibitory concentration: 14.7 ug/mL
Compound 4: the middle estimate sits 1.4-fold (0.13 log units) above what was measured; low and high end bracket the measured number.
By their numbers in this assay, from the lowest: compounds 4, 3 and 1 (each within the scatter of the next). At a limit, above all of these: compound 2.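

In this assay, the ring with no group at all now joins the comparison, and neither step to it counts as a change: a 1.2-fold lower number from compound 3 to compound 4 (0.09 log units; within the scatter) and a 1.6-fold lower number from compound 1 to compound 4 (0.21 log units; within the scatter). At this place, para to a large group, hydrogen, fluoro and ethoxy therefore give numbers that cannot be told apart, so this level of cytotoxicity does not depend on having any of these groups there. The one clear shift is an at least 6.8-fold lower number from compound 2 to compound 4 (0.83 log units; beyond the scatter), so among these compounds a fluoro goes with a real difference only where compound 2 carries it, and compound 2 stands at a limit rather than at a number: the limit of > 100 ug/mL in this assay, at which 1 of the 4 values shown sits.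

Going by these compounds, it remains open whether any group at this place can move the number, since an amine, a carboxylic acid or a longer chain there might not behave like the three groups seen so far. On these data alone, with compound 2 at a limit, the true size of its shift also stays unknown, and only a lower bound on it can be read.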